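A few compounds are considered here, and "the series" means these few. Any claim that something is new, unique, unknown or untested is made for them only; others in the source may bear on it.

Measured compounds in an assay on HEK293 cells for positive allosteric modulation of metabotropic glutamate receptor 3 (Rattus norvegicus), read by thallium flux, with a stated time of 2.5 min; a higher number here means a larger maximal response, a lower number a smaller maximal response:

compound 1 `Cc1c(OCCCCOc2ccc(C(=O)O)cc2Cl)ccc(C(=O)CC2CCCC2)c1O`: 27.4%
compound 2 `Cc1c(OCCCCOc2ccc(C(=O)O)cc2)ccc(C(=O)CC(C)C)c1O`: 51.9%
compound 3 `Cc1c(OCCCCOc2ccc(C(=O)O)cc2)ccc(C(=O)CC(C)C)c1C`: 16.6%

Compound 3 stands lowest of the three in this assay; its nearest neighbour is compound 1, and compound 2 lies furthest away. Among the compounds with values here, the one single-point step available within the set is a number 35.3 percentage points lower from compound 2 to compound 3 (beyond the scatter), and it concerns the core of compound 3, not the carboxyphenyl end of the chain.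

Compound 4 `Cc1c(OCCCCOc2ccc(C(=O)O)c(Cl)c2)ccc(C(=O)CC(C)C)c1C` is not yet measured. It differs from compound 3 by chloro in place of hydrogen on an aromatic carbon, the chloro entering on the aromatic ring that carries the carboxy group, ortho to that group and meta to a large group. Within the data shown here, no measured step bears directly on this change. Among the measured compounds shown here, compound 1 also carries a chloro on the carboxyphenyl ring, but it differs from compound 2 in two places at once, so its values and those of compound 2 show only that both lie above compound 3.

For the measured compounds named here, with no relevant step in hand, the expectation for compound 4 is a step of a number 1.4 percentage points higher from compound 3 to compound 4 (within the scatter), that is, no movement beyond the scatter. Compound 4 is therefore estimated at 18%, with a range from 8% to 32%.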

Compound 4, largest response reached (reported as percent of maximum), in percent of the reference or control that the assay uses: 12%
For compound 4 the middle estimate is 6 percentage points above the measured one; measured number inside the range.
By their numbers in this assay, from the lowest: compounds 4 and 3 (each within the scatter of the next); then compound 1; then compound 2.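

In this assay, within the data shown here, the change from 4-carboxyphenyl to 4-carboxy-3-chlorophenyl on the core of compound 3 gives a number 4.6 percentage points lower from compound 3 to compound 4 (within the scatter), the first direct reading of a chloro on the aromatic carbon ortho to the carboxy group. On this core, which carries methyl on the aromatic carbon where compound 2 carries hydroxy, the step does not separate the two compounds, so the series shows a chloro tolerated at this position without a measurable gain or loss in maximal response. No measurement in hand speaks to why this is so.

As far as these compounds go, whether the same chloro would read alike on the hydroxy-bearing core of compound 2 stays open, since compound 1 has its chloro at another place on the carboxyphenyl ring and also differs in the ketone side chain. Also open, from the compounds shown here alone, is what a fluoro, a methoxy or a nitrile would do at this position, and whether an amide or a tetrazole could stand in place of the carboxylic acid alongside the chloro.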